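Swapping a methoxyphenyl for a naphthyl on a shared core

The source may hold more compounds than are shown below. What is called first, only, known or untested is meant among the compounds shown, and "the series" means these compounds.

Of the compounds shown here, three built on one shared core have been measured in a physicochemical assay for acid dissociation. Compound 1 `COc1cccc(Oc2ccc3c(NCCCNCc4ccco4)ccnc3c2)c1` gives 9.28, compound 2 `Fc1ccc(Oc2ccc3c(NCCCNCc4ccco4)ccnc3c2)cc1` gives 9.28, and compound 3 `COc1ccc(-c2ccc3c(NCCCNCc4ccco4)ccnc3c2)cc1` gives 9.47. On the numbers as written, compound 3 stands at the top, but only by margins that the assay cannot resolve: the step from compound 1 to compound 3 is a number 0.19 log units higher from compound 1 to compound 3 (within the scatter), and the step from compound 2 to compound 3 is a number 0.19 log units higher from compound 2 to compound 3 (within the scatter). The step from compound 1 to compound 2 is no change at the digits printed from compound 1 to compound 2 (within the scatter), so none of the three numbers can be told apart from the others.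

Compound 4 `c1coc(CNCCCNc2ccnc3cc(-c4cccc5ccccc45)ccc23)c1` has not yet been measured. It differs from compound 3 in one place: naphthalen-1-yl in place of 4-methoxyphenyl on an aromatic carbon. The three measured steps each exchange one aromatic group for another at this same region of the core, and all of them, no change at the digits printed from compound 1 to compound 2 (within the scatter), a number 0.19 log units higher from compound 1 to compound 3 (within the scatter) and a number 0.19 log units higher from compound 2 to compound 3 (within the scatter), stayed within the scatter. Nothing in these data points to a shift beyond the scatter for this assay when the group at that position is changed again.

Compound 4 is therefore expected to give 9.45, with a range from 9.15 to 9.75. The expected step from compound 3 to compound 4 is a number 0.02 log units lower from compound 3 to compound 4 (within the scatter), which would lie within the scatter.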

Compound 4, acid dissociation constant: 9.47
Compound 4: the middle estimate sits 0.02 log units below what was measured, and the stated range covers the measured number.
By their numbers in this assay, from the lowest: compounds 1, 2, 3 and 4 (each within the scatter of the next).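

In this assay, replacing 4-methoxyphenyl with naphthalen-1-yl swaps one six-membered aromatic ring for two and removes a hydrogen-bond acceptor, yet the outcome is no change at the digits printed from compound 3 to compound 4 (within the scatter) and the position still shows no measurable response to the change. Among the compounds shown here, the earlier steps covered only single-ring groups, so this is the first sign that a larger fused group of carbon only on this aromatic carbon also leaves the number where it was. Against the two oxygen-linked groups, naphthalen-1-yl in place of 4-fluorophenoxy gives a number 0.19 log units higher from compound 2 to compound 4 (within the scatter) and naphthalen-1-yl in place of 3-methoxyphenoxy gives a number 0.19 log units higher from compound 1 to compound 4 (within the scatter) and all four compounds therefore remain indistinguishable, with nothing available to explain the lack of response.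

Every group shown at this position is aromatic, so it remains open whether an amine or a carboxylic acid on the same carbon would shift the reading in this assay beyond the scatter. The chain shared by all four compounds is also constant, which leaves open what a longer chain there would do.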